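A few compounds are considered here, and "the series" means these few. Any claim that something is new, unique, unknown or untested is made for them only; others in the source may bear on it.

Measured in an ADME assay on Vero cells (Chlorocebus sabaeus) for cytotoxicity, with a stated time of 5 days; a lower number here means a stronger inhibitor, a higher number a weaker inhibitor:
- compound 1 `C=CCNc1nc(N)nc2c1ncn2[C@H]1C[C@H](N=[N+]=[N-])[C@@H](CO)O1`: > 100000 nM
- compound 2 `[N-]=[N+]=N[C@H]1C[C@H](n2cnc3c(NC4CC4)nc(N)nc32)O[C@@H]1CO`: > 100000 nM
- compound 3 `CC(CO)Nc1nc(N)nc2c1ncn2[C@H]1C[C@H](N=[N+]=[N-])[C@@H](CO)O1`: > 100000 nM

Each of these three results is a limit and not a number. Compound 3 gives > 100000 nM, which is a limit. It therefore stands with the other two compounds, as the limit of > 100000 nM in this assay, at which 3 of the 3 values shown sit, records, and no order can be read among them.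

The next compound is compound 4 `C=CCN(C)c1nc(N)nc2c1ncn2[C@H]1C[C@H](N=[N+]=[N-])[C@@H](CO)O1`. Here allyl(methyl)amino takes the place of (1-(hydroxymethyl)ethyl)amino on an aromatic carbon of the shared core: allyl(methyl)amino in place of (1-(hydroxymethyl)ethyl)amino on an aromatic carbon.

Among the compounds with values here, three measured steps bear on this change, since each swaps the group on a nitrogen on an aromatic ring: a step that the two limits leave unreadable from compound 1 to compound 2, a step that the two limits leave unreadable from compound 1 to compound 3 and a step that the two limits leave unreadable from compound 2 to compound 3. None of them has a readable size, so they offer no direction and no measure of how far such a swap can move this assay. All they show is that three different groups at this place leave the result at the limit. The expectation is therefore no step beyond the scatter, with compound 4 most likely reported as a limit too. The expected step is a number no higher from compound 3 to compound 4 (the limit leaves the size open). For compound 4 the estimated value is 100000 nM, with an expected range of 40000 nM to 200000 nM.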

Compound 4, half-maximal inhibitory concentration: 32000 nM
Beside the measured number, compound 4's estimate is 3.1-fold (0.49 log units) above it; measured number below the stated range.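

Within the data shown here, compound 4 is the first compound here whose result in this assay is a number and not a limit, which shows that the group on this aromatic carbon of the shared core can bring the result down into the readable range. Allyl(methyl)amino gives an at least 3.1-fold lower number from compound 3 to compound 4 (0.49 log units; beyond the scatter) and an at least 3.1-fold lower number from compound 2 to compound 4 (0.49 log units; beyond the scatter) while the smallest of the changes, methyl in place of hydrogen on the nitrogen on the aromatic ring, gives an at least 3.1-fold lower number from compound 1 to compound 4 (0.49 log units; beyond the scatter) and that single added methyl is thus enough to produce a measurable change in this assay. Compound 1, compound 2 and compound 3 still rest on a limit and not on a number: the limit of > 100000 nM in this assay, at which 3 of the 4 values shown sit.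

As far as these compounds go, the steps among those three compounds cannot be read, and each new step gives only a minimum, so the full size of the change stays unknown. From the compounds shown here alone, it also remains open whether a methyl on the nitrogen of the cyclopropylamino group of compound 2 would act the same way, and what dimethylamino or an ethyl in place of that methyl would give.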